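This account rests on a few compounds, and the source may have more. Where it says the series, first, only, none or still open, it means among the compounds named here.

In a functional assay on HepG2 cells (Homo sapiens) for antiproliferative activity, read by MTT assay, with a stated time of 24 h (on this read-out higher numbers stand for weaker inhibition and lower numbers for stronger inhibition), compound 1 `FC(F)(F)c1ccc(-c2nn(-c3ccccc3)cc2-c2nc3ccccc3[nH]2)cc1`, with a hydrogen on the aromatic nitrogen, gives 6030 nM. Compound 2 `Cc1ccc(C)c(S(=O)(=O)n2c(-c3cn(-c4ccccc4)nc3-c3ccc(C(F)(F)F)cc3)nc3ccccc32)c1`, with (2,5-dimethylphenyl)sulfonyl on that nitrogen, gives 330 nM, and compound 3 `O=[N+]([O-])c1ccc(S(=O)(=O)n2c(-c3cn(-c4ccccc4)nc3-c3ccc(C(F)(F)F)cc3)nc3ccccc32)cc1`, with (4-nitrophenyl)sulfonyl there, gives 1070 nM. Compound 3 therefore holds the middle place of the three numbers. Compound 4 `O=S(=O)(c1ccc(Br)cc1)n1c(-c2cn(-c3ccccc3)nc2-c2ccc(C(F)(F)F)cc2)nc2ccccc21` differs from it by one change on the sulfonyl aryl ring: bromo in place of nitro on an aromatic carbon. This puts bromo in place of nitro on an aromatic carbon, turning 4-nitrophenyl into 4-bromophenyl.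

Both sulfonyl groups lowered the number, with an 18-fold lower number from compound 1 to compound 2 (1.26 log units; beyond the scatter) and a 5.6-fold lower number from compound 1 to compound 3 (0.75 log units; beyond the scatter). These steps show that compound 4 keeps a substitution that helped twice. Within the data shown here, the closest precedent is a 3.2-fold higher number from compound 2 to compound 3 (0.51 log units; beyond the scatter), the only measured change of the aryl group on sulfur. Among the measured compounds shown here, no measured compound carries bromo, so the direction is uncertain. A small move towards compound 2 is expected, probably within the scatter.

The expected change is a 1.5-fold lower number from compound 3 to compound 4 (0.18 log units; within the scatter). For compound 4 the estimated value is 700 nM, with an expected range from 250 nM to 1900 nM.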

Compound 4, half-maximal inhibitory concentration: 2160 nM
Compound 4: middle estimate off by 3.1-fold (0.49 log units), on the low side; the measured number lies above the stated range.
By their numbers in this assay, from the lowest: compound 2; then compound 3; then compound 4; then compound 1.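

In this assay, bromo in place of nitro gives a 2.0-fold higher number from compound 3 to compound 4 (0.31 log units; beyond the scatter), so the group on this aromatic carbon matters, and the number moves further from that of the best compound shown rather than towards it. The comparison with the dimethyl-substituted aryl group, a 6.5-fold higher number from compound 2 to compound 4 (0.82 log units; beyond the scatter), is the largest gap yet among the aryl groups on sulfur. The sulfonyl substitution still pays with a 2.8-fold lower number from compound 1 to compound 4 (0.45 log units; beyond the scatter), so all three sulfonyl groups give lower numbers than hydrogen, although the (4-bromophenyl)sulfonyl group gains the least.

Going by these compounds, whether a methoxy group or an amine in this same place would fall nearer to nitro or to bromo stays open, as does which methyl of the 2,5-dimethylphenyl group matters. Nothing measured here explains the order of these aryl groups.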